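The compounds below may be only part of what the source reports. "The series", "measured", "known", "first", "only" and "open" are said of these compounds alone.

Working notes on the series. The shared core is a hydroxy diaryl unit on a triazole carbonyl amide of a substituted piperidine, and its ring substituents are varied.

Compound 1 `C#CCO[C@@H]1CC[C@H](Cc2ccccc2)N(C(=O)n2ncc(C(O)(c3ccc(F)cc3)c3ccc(F)cc3)n2)C1` gives 2.51 nM in an assay on isolated protein for inhibition of Monoacylglycerol lipase ABHD6 (Homo sapiens), read by fluorescence; on this read-out higher numbers stand for weaker inhibition and lower numbers for stronger inhibition. Compound 2 `COc1ccc(CC2CCCCN2C(=O)n2ncc(C(O)(c3ccc(F)cc3)c3ccc(F)cc3)n2)cc1` gives 251 nM in this assay, the highest of the two numbers shown and a gap from compound 1 that lies beyond the scatter. Compound 3 `COC(c1ccc(F)cc1)(c1ccc(F)cc1)c1cnn(C(=O)N2CCCCC2Cc2ccccc2)n1` gives > 10000 nM in this assay, which is a limit of the assay and not a number, (the limit of > 10000 nM in this assay, at which 1 of the 3 values shown sits).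

Compound 4 `O=C(N1CCCCC1COc1ccc(F)cc1)n1ncc(C(O)(c2ccc(F)cc2)c2ccc(F)cc2)n1` is not yet measured. It differs from compound 2 in one place: 4-fluorophenoxy in place of 4-methoxyphenyl on a saturated chain carbon bound to a saturated ring carbon. No measured pair covers this kind of change, so no step size can be drawn from the numbers shown; compound 1 and compound 2 differ in two places at once.

The change from compound 2 to compound 4 is therefore expected to stay within the scatter, a 1.2-fold higher number from compound 2 to compound 4 (0.08 log units; within the scatter), with a wide range allowed. Compound 4 is estimated at 300 nM in this assay, from 60 nM to 2000 nM.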

Compound 4, half-maximal inhibitory concentration: 200 nM
The estimate for compound 4 lay 1.5-fold (0.18 log units) above the measured number, and the stated range covers the measured number.
By their numbers in this assay, from the lowest: compound 1; then compounds 4 and 2 (each within the scatter of the next). At a limit, above all of these: compound 3.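

At this position, on a saturated chain carbon bound to a saturated ring carbon, the exchange of 4-methoxyphenyl for 4-fluorophenoxy gives a 1.3-fold lower number from compound 2 to compound 4 (0.10 log units; within the scatter) in this assay. This is the only single-place step shown at this position, and it leaves the two compounds indistinguishable in this read-out, even though the oxygen sits differently in the two side chains and the ring substituent is not the same. Nothing measured on these compounds bears on this step, so no cause can be assigned to it.

From the compounds shown here alone, how an amine, a carboxylic acid or a longer chain at this place would read remains open. Also open, going by these compounds, is whether the same exchange would read alike on the more substituted ring of compound 1.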